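The compounds below may be only part of what the source reports. "The series", "measured", "known", "first", "only" and "open" are said of these compounds alone.

Values in a functional assay on MKN-45 cells (Homo sapiens) for inhibition, with a stated time of 72 h (a lower number here means a stronger inhibitor, a higher number a weaker inhibitor), so far:
compound 1 `COc1cc(C(=O)n2ccc3ccccc32)cc(OC)c1OC` gives 5200 nM
compound 2 `COc1cc(C(=O)c2cccc3[nH]ccc23)cc(OC)c1OC` gives 49.1 nM
compound 3 `COc1cc(C(=O)c2ccc3[nH]ccc3c2)cc(OC)c1OC` gives 88 nM

Compound 3 (88 nM) lies within the scatter of compound 2 (49.1 nM), while compound 1 (5200 nM) stands far from both, on the weak side.

Compound 4 `COc1cc(C(=O)c2ccc3c(ccn3CC(=O)O)c2)cc(OC)c1OC` departs from compound 3 at one place, counted as carboxymethyl in place of hydrogen on an aromatic nitrogen. Among the compounds with values here, no measured pair isolates this change. Within the data shown here, compound 1 (5200 nM) is the only measured compound without hydrogen on that nitrogen, but there the carbonyl itself sits on it, so it offers only a loose guide. Weaker inhibition beyond the scatter is still the expectation in this assay, with an expected step of a 17-fold higher number from compound 3 to compound 4 (1.23 log units; beyond the scatter) (uncertain in size, firmer in direction). The estimated value for compound 4 is 1500 nM (expected range 250 nM to 9000 nM).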

Compound 4, half-maximal inhibitory concentration: 396 nM
Compound 4: middle estimate off by 3.8-fold (0.58 log units), on the high side; measured number inside the range.
By their numbers in this assay, from the lowest: compounds 2 and 3 (each within the scatter of the next); then compound 4; then compound 1.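

Carboxymethyl in place of hydrogen on the aromatic nitrogen gives a 4.5-fold higher number from compound 3 to compound 4 (0.65 log units; beyond the scatter) in this assay, and this is the only measured pair that isolates a change at this position. The hydrogen on that nitrogen is therefore not required for inhibition, since compound 4 still gives 396 nM in this assay, although the change carries a cost beyond the scatter. No measurement at hand accounts for the size or direction of this step.

Still open, from the compounds shown here alone, is whether the step follows from losing the hydrogen or from the entering group, which a methyl group, a longer chain ending in a carboxylic acid, or an amine on the same nitrogen would help separate. Also open, going by these compounds, is whether carboxymethyl on the nitrogen of compound 2 would give a step of similar size.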